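The compounds below may be only part of what the source reports. "The series", "measured", "known", "first", "only" and "open" are said of these compounds alone.

Three compounds built on one shared core have been examined in a physicochemical assay for solubility, read by HPLC, with a stated time of 15 min; on this read-out lower numbers stand for lower solubility and higher numbers for higher solubility. Compound 1 `CC(C)(C)c1[nH]cnc1/C=c1\[nH]c(=O)/c(=C/c2ccccc2)nc1OCOC(=O)CCCc1cn([C@@H]2O[C@H](CO)[C@H](O)[C@H](O)[C@H]2O)nn1` gives 7.5 ug/mL in this assay. Compound 2 `CC(C)(C)c1[nH]cnc1/C=c1\[nH]c(=O)/c(=C/c2ccccc2)nc1OCOC(=O)CCCc1cn(CC(=O)O)nn1` gives 590 ug/mL. Compound 3 `CC(C)(C)c1[nH]cnc1/C=c1\[nH]c(=O)/c(=C/c2ccccc2)nc1OCOC(=O)CCCc1cn([C@@H](CC(=O)O)C(=O)O)nn1` reaches only a limit of the assay, > 100000 ug/mL. Each measured step is large: a 79-fold higher number from compound 1 to compound 2 (1.90 log units; beyond the scatter), an at least 160-fold higher number from compound 2 to compound 3 (2.22 log units; beyond the scatter), and across both changes an at least 13000-fold higher number from compound 1 to compound 3 (4.12 log units; beyond the scatter). Compound 4 `CC(C)(C)c1[nH]cnc1/C=c1\[nH]c(=O)/c(=C/c2ccccc2)nc1OCOC(=O)CCCc1cn([C@H](CCC(=O)O)C(=O)O)nn1` differs from compound 3 by 1,3-dicarboxypropyl in place of 1,2-dicarboxyethyl on an aromatic nitrogen. The entering group is a close relative of the leaving one, so this change is far smaller than any measured step, and since compound 3 already sits at the limit of > 100000 ug/mL in this assay, at which 1 of the 3 values shown sits, no step beyond the scatter is expected: a number no higher from compound 3 to compound 4 (the limit leaves the size open). Compound 4 is therefore estimated at 100000 ug/mL, between 30000 ug/mL and 100000 ug/mL.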

Compound 4, solubility: > 100000 ug/mL
Compound 4: only a limit was reported; the forecaster's own chance of this, stated with the estimate: 80%; the middle value lies on the limit itself.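

In this assay compound 4 gives > 100000 ug/mL, which is again a limit of the assay. The steps between compound 3 and compound 4 therefore cannot be read, and the read-out no longer separates these two compounds: the limit of > 100000 ug/mL in this assay, at which 2 of the 4 values shown sit. The 1,3-dicarboxypropyl group on the aromatic nitrogen, with 5 carbon against 4 in 1,2-dicarboxyethyl, keeps the read-out at that limit, with an at least 160-fold higher number from compound 2 to compound 4 (2.22 log units; beyond the scatter) and an at least 13000-fold higher number from compound 1 to compound 4 (4.12 log units; beyond the scatter).

From the compounds shown here alone, what an amine in place of one carboxylic acid would give at this position stays open, as does whether a still longer chain would stay at the limit.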